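The source may report more compounds than this note shows. Statements on the series, on what has been measured and on what is new or still open speak of the compounds shown alone.

Measured so far in a functional assay on SW-620 cells (Homo sapiens) for inhibition, read by sulforhodamine B assay, with a stated time of 48 h; a higher number here means a weaker inhibitor of growth, a lower number a stronger inhibitor of growth:
- compound 1 `Cc1ccc(C2=NN(c3ccc(S(C)(=O)=O)cc3)C(=O)CC2)cc1`: > 100000 nM
- compound 2 `Cc1cc(O)ccc1C1=NN(c2ccc(S(C)(=O)=O)cc2)C(=O)CC1`: > 100000 nM

Compound 2 stands at a limit, > 100000 nM, and not at a number. Compound 1 also stands at a limit, > 100000 nM. Compound 3 `CCc1ccc(C2=NN(c3ccc(S(C)(=O)=O)cc3)C(=O)CC2)cc1` has 4-ethylphenyl in place of 4-hydroxy-2-methylphenyl on a carbon with a double bond to nitrogen. For the measured compounds named here, the one measured step, a step that the two limits leave unreadable from compound 1 to compound 2, bears on this change but gives no size to carry over. Going by the values given here, the only guide is the limit of > 100000 nM in this assay, at which 2 of the 2 values shown sit, so no step beyond the scatter is expected in this assay, and another limit is likely. The expected step is a number no higher from compound 2 to compound 3 (the limit leaves the size open). Compound 3 is estimated at 100000 nM, within an expected range of 40000 nM to 200000 nM.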

Compound 3, concentration for total growth inhibition: > 100000 nM
Compound 3 ended at the assay's limit; the forecaster's own chance of this, stated with the estimate: 85%; the middle value sits exactly at the limit.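

In this assay, for the compounds shown here, compound 1, compound 2 and compound 3 all stand at a limit and not at a number, and no step among them can be read. The compounds shown leave open whether any change on the shared core would give a measurable concentration for total growth inhibition.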